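Swapping chloro for cyano on the phenyl ring

The source may hold more compounds than are shown below. What is called first, only, known or untested is meant among the compounds shown, and "the series" means these compounds.

Measured compounds, in a functional assay on the whole organism (integument) for inhibition, with Chilo suppressalis as the target, read by scintillation counting, with a stated time of 72 h; a higher number here means a weaker inhibitor, a lower number a stronger inhibitor:
Compound 1 `O=C(Nc1nnc(-c2ccc(Cl)cc2)s1)c1c(Cl)cccc1Cl` gives 380 nM.
Compound 2 `COc1cccc(OC)c1C(=O)Nc1nnc(-c2ccc(Cl)cc2)s1` gives 58.9 nM.
Compound 3 `CCOc1ccccc1C(=O)Nc1nnc(-c2ccc(Cl)cc2)s1` gives only a limit, > 5010 nM.

Compound 2 stands lowest of the two numbers that were obtained; compound 1 sits clearly higher, beyond the usual scatter. Compound 3 reached only the upper limit of the measurement (the limit of > 5010 nM in this assay, at which 1 of the 3 values shown sits), so nothing can be said of its number. For the measured compounds named here, no single-change step between measured compounds has been worked out, so the evidence for the next move is thin.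

Compound 4 `COc1cccc(OC)c1C(=O)Nc1nnc(-c2ccc(C#N)cc2)s1` differs from compound 2 in one place: cyano in place of chloro on an aromatic carbon. Put another way, 4-chlorophenyl becomes 4-cyanophenyl, the rest of the shared core staying untouched. Going by the values given here, with no measured step of this kind to lean on, the expectation is a small change, within or close to the scatter, in no settled direction. The step that this estimate means, a 1.5-fold higher number from compound 2 to compound 4 (0.18 log units; within the scatter), is expected to stay modest. Compound 4 is therefore estimated at 90 nM, somewhere between 30 nM and 400 nM.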

Compound 4, half-maximal inhibitory concentration: 209 nM
The estimate for compound 4 lay 2.3-fold (0.37 log units) below the measured number; low and high end bracket the measured number.
By their numbers in this assay, from the lowest: compound 2; then compounds 4 and 1 (each within the scatter of the next). At a limit, above all of these: compound 3.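

The earlier compounds shown here all carry 4-chlorophenyl, so they varied only the other end of the molecule and showed nothing about this position. In this assay, the change from 4-chlorophenyl to 4-cyanophenyl gives a 3.5-fold higher number from compound 2 to compound 4 (0.55 log units; beyond the scatter) and so shows that this position does affect the number, with chloro the better of these two groups when the rest of compound 2 stays fixed. The loss is modest, so this position tolerates a nitrile with the inhibitor still measurable, but nothing measured here accounts for the rise.

Only chloro and cyano are shown at this position, so it remains open how a methyl, a methoxy or an amine would fare there. From the compounds shown here alone, it is also open whether the same swap would cost as much on compound 1, whose other end differs.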